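A few compounds are considered here, and "the series" means these few. Any claim that something is new, unique, unknown or untested is made for them only; others in the source may bear on it.

Compound 1, `Cc1cc(NC(=O)Nc2ccccc2OC(F)(F)F)c2ccccc2n1`, is reported in an ADME assay on HEK293 cells (Homo sapiens) for cytotoxicity, with a stated time of 72 h (on this read-out lower numbers stand for an effect already at smaller amounts and higher numbers for an effect only at larger amounts of compound), only as the limit > 25000 nM.
Compound 2, `CC(=O)c1ccc(NC(=O)Nc2cc(C)nc3ccccc23)cc1`, is likewise reported in this assay only as the limit > 25000 nM.
Compound 3, `COc1ccc(NC(=O)Nc2cc(C)nc3ccccc23)cc1F`, also stops in this assay at the limit > 25000 nM.

Compound 2 thus stands where every value shown stands, at the limit of > 25000 nM in this assay, at which 3 of the 3 values shown sit, and none of the three is a number. Compound 4, `Cc1cc(NC(=O)Nc2ccc(N)cc2)c2ccccc2n1`, differs from compound 2 by amino in place of acetyl on an aromatic carbon. For the measured compounds named here, no step between measured compounds exists here, so the size of this change cannot be read from the data. In this assay no step beyond the scatter is expected, because all values shown sit at the limit of > 25000 nM in this assay, at which 3 of the 3 values shown sit. The estimate for compound 4 is 30000 nM, between 10000 nM and 100000 nM, which as an expected step means a step that the limit leaves unreadable from compound 2 to compound 4.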

Compound 4, half-maximal effective concentration: > 25000 nM
Compound 4 was reported as a limit; the forecaster's own chance of this, stated with the estimate: 70%; the middle value lies beyond the limit too.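

For the compounds shown here, compound 4, like compound 2, is reported only as a limit, so no step between these two compounds can be read: the limit of > 25000 nM in this assay, at which 4 of the 4 values shown sit.

The compounds shown leave open whether amino in place of acetyl on an aromatic carbon changes anything in this assay, and at what concentration any of them would show an effect.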